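The source may hold more compounds than are shown below. What is called first, only, known or untested is meant among the compounds shown, and "the series" means these compounds.

Compound 1 `O=C1N=C(C2C(=O)c3ccccc3C2=O)CC(c2ccccc2)N1` and compound 2 `O=C1N=C(C2C(=O)c3ccccc3C2=O)CC(c2cccc([N+](=O)[O-])c2)N1` share one core and differ at a single aromatic carbon. In a functional assay on the whole organism for inhibition, with Rattus norvegicus as the target, read by paw edema, with stated times of 30 min and 2 h, at a dose of 10 mg/kg by the oral route (on this read-out higher numbers stand for more inhibition at the one dose given (going by the name of the read-out) and lower numbers for less inhibition), compound 1 gives 33%, and compound 2 gives 36%. The step between them, a number 3 percentage points higher from compound 1 to compound 2 (within the scatter), stays within the scatter of the method. Within the data shown here, compound 2 thus holds the upper of the two numbers measured so far, but its only neighbour, compound 1, sits within the scatter of it, so the two cannot be told apart.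

Compound 3 `O=C1N=C(C2C(=O)c3ccccc3C2=O)CC(/C=C/c2ccccc2)N1` has not yet been measured in this assay. It differs from compound 2 by 2-phenylethenyl in place of 3-nitrophenyl on a saturated ring carbon. Among the measured compounds shown here, the one measured step concerns a different place and a different change, so no measured step bears directly on this one; the only information is that the single change seen so far, on the aromatic ring, left the read-out unchanged within the scatter. On that basis a step of no more than the scatter is expected, namely a number 4 percentage points lower from compound 2 to compound 3 (within the scatter). Compound 3 is therefore estimated at 32% in this assay, within a range from 15% to 50%.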

Compound 3, a percentage reported as inhibition, in the whole organism at one dose (the size of the read-out at that dose, not a potency): 32%
Compound 3: the middle estimate sits on the measured number at the digits printed; the measured number falls inside the stated range.
By their numbers in this assay, from the lowest: compounds 3, 1 and 2 (each within the scatter of the next).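

In this assay the saturated ring carbon of the shared core, next to the ring nitrogen, accepts a change of group with a number 4 percentage points lower from compound 2 to compound 3 (within the scatter) when 2-phenylethenyl takes the place of 3-nitrophenyl and with a number 1 percentage points lower from compound 1 to compound 3 (within the scatter) when it takes the place of phenyl. Compound 1 and compound 2 differ only at an aromatic carbon and could say nothing about this position, whereas these two steps show that neither a change from a directly attached phenyl to 2-phenylethenyl nor the loss of the nitrogen and oxygen of 3-nitrophenyl separates the read-outs at this dose. No measurement shown here accounts for this lack of separation at this position.

As far as these compounds go, all three groups at this carbon carry a six-membered aromatic ring of carbon only, so it stays open whether an amine, a carboxylic acid or a longer saturated chain in that place would give a step beyond the scatter. With one oral dose as the only read-out, the compounds shown also leave open whether their potencies differ at other doses.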